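A few compounds are considered here, and "the series" means these few. Any claim that something is new, unique, unknown or untested is made for them only; others in the source may bear on it.

Measured in a functional assay on DU-145 cells (Homo sapiens) for cytotoxicity, read by MTT assay, with a stated time of 24 h; a higher number here means a weaker inhibitor, a lower number a stronger inhibitor:
- Compound 1 `COc1ccc(/C=C2\CN(C(=S)SCc3cn(Cc4ccccc4F)nn3)C/C(=C\c3ccc(OC)cc3)C2=O)cc1`: 54500 nM
- Compound 2 `O=C1/C(=C/c2ccccc2F)CN(Cc2cn(Cc3ccccc3F)nn2)C/C1=C\c1ccccc1F`: 10600 nM
- Compound 3 `COc1ccc(/C=C2\CN(Cc3cn(Cc4cccc(Cl)c4)nn3)C/C(=C\c3ccc(OC)cc3)C2=O)cc1`: 15400 nM

Compound 1 has the highest number of the three, which makes it the weakest inhibitor here, and its gaps to compound 2 and to compound 3 both lie beyond the usual scatter.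

Compound 4 `COc1ccc(/C=C2\CN(C(=S)SCc3cn(Cc4ccc(F)cc4)nn3)C/C(=C\c3ccc(OC)cc3)C2=O)cc1` differs from compound 1 in one place: 4-fluorophenyl in place of 2-fluorophenyl on a saturated chain carbon bound to an aromatic nitrogen. Here 4-fluorophenyl stands in place of 2-fluorophenyl on a saturated chain carbon bound to an aromatic nitrogen. Among the compounds with values here, no measured pair shows a change of this kind, so the expectation in this assay is no step beyond the scatter, with only a slight lean towards a lower number. The expected step is small: a 1.2-fold lower number from compound 1 to compound 4 (0.08 log units; within the scatter). For compound 4 the estimated value is 45000 nM, with an expected range of 22000 nM to 90000 nM.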

Compound 4, half-maximal inhibitory concentration: 74600 nM
Compound 4: the middle estimate sits 1.7-fold (0.22 log units) below what was measured; low and high end bracket the measured number.
By their numbers in this assay, from the lowest: compounds 2 and 3 (each within the scatter of the next); then compounds 1 and 4 (each within the scatter of the next).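

In this assay, replacing 2-fluorophenyl with 4-fluorophenyl on the saturated chain carbon bound to an aromatic nitrogen gives a 1.4-fold higher number from compound 1 to compound 4 (0.14 log units; within the scatter), a step within the scatter. Within the data shown here, this is the only pair here that differs in one place, and it shows that this assay cannot tell these two fluorophenyl groups apart on the core of compound 1. Nothing available explains the result.

On these data alone, it remains open whether an unsubstituted phenyl or a cyclohexyl at this place would shift the number. The same fluorine swap on the core of compound 2 is also untested here.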